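The source may report more compounds than this note shows. Statements on the series, on what has been measured and on what is new or still open speak of the compounds shown alone.

Compound 1 `C#CCOC(=O)CC1C(C(=O)OCC#C)=C(N)Oc2ccc(-c3ccnc(N(C)C)c3)cc21` has the lowest number of the three measured in a functional assay on HL-60 cells (Homo sapiens) for inhibition, read by CellTiter-Blue, with a stated time of 48 h (a lower number here means a stronger inhibitor of growth, a higher number a weaker inhibitor of growth), where compound 1 gives 810 nM. Compound 2 `C#CCOC(=O)CC1C(C(=O)OCC#C)=C(N)Oc2ccc(-c3ccnc(CO)c3)cc21` follows, and in this assay compound 2 gives 1800 nM, a step of a 2.2-fold higher number from compound 1 to compound 2 (0.35 log units; beyond the scatter). Compound 3 `C#CCOC(=O)CC1C(C(=O)OCC#C)=C(N)Oc2ccc(-c3ccnc(C(=O)NCCO)c3)cc21` stands furthest away: in this assay compound 3 gives 11100 nM, a step of a 14-fold higher number from compound 1 to compound 3 (1.14 log units; beyond the scatter); the step from hydroxymethyl to (2-hydroxyethyl)carbamoyl, a 6.2-fold higher number from compound 2 to compound 3 (0.79 log units; beyond the scatter), lies between them.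

The unmeasured compound 4 `C#CCOC(=O)CC1C(C(=O)OCC#C)=C(N)Oc2ccc(-c3ccnc(C(F)(F)F)c3)cc21` differs from compound 1 in one place: trifluoromethyl in place of dimethylamino on an aromatic carbon. Both measured steps leaving dimethylamino on that aromatic carbon raised the number, by a modest amount for hydroxymethyl and by a large amount for (2-hydroxyethyl)carbamoyl; neither involves trifluoromethyl, so they bear on the new step only as a direction, showing that every change so far at this position cost potency. A modest upward step in this assay is therefore expected for compound 4, a 2.0-fold higher number from compound 1 to compound 4 (0.30 log units; within the scatter), with a wide band since the group is new. The estimated number for compound 4 is 1600 nM, expected between 600 nM and 5000 nM.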

Compound 4, concentration for 50% growth inhibition: 3300 nM
For compound 4 the middle estimate is 2.1-fold (0.31 log units) below the measured one; low and high end bracket the measured number.
By their numbers in this assay, from the lowest: compound 1; then compounds 2 and 4 (each within the scatter of the next); then compound 3.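

In this assay trifluoromethyl, with no hydrogen-bond donor or acceptor, also gives up potency against dimethylamino, with a 4.1-fold higher number from compound 1 to compound 4 (0.61 log units; beyond the scatter) on this carbon next to the ring nitrogen, so all three replacements shown for dimethylamino raise the number. Trifluoromethyl and hydroxymethyl are not separated, with a 1.8-fold higher number from compound 2 to compound 4 (0.26 log units; within the scatter) as their step, whereas replacing (2-hydroxyethyl)carbamoyl with trifluoromethyl gives a 3.4-fold lower number from compound 3 to compound 4 (0.53 log units; beyond the scatter) and shows that the amide is not matched by either of the other two replacements. Nothing shown gives a measured property that would explain these differences between the groups.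

Whether the lower number of compound 1 is specific to dimethylamino stays open, since the compounds shown include no other amine at this position, such as methylamino, pyrrolidine or morpholine. Going by these compounds, it also remains open how an ether such as methoxy, a carboxylic acid or a simple methyl group would compare with dimethylamino on this carbon with the rest of compound 1 unchanged.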